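Swapping a thiazolylamine for an imidazolylmethyl arm

The compounds below may be only part of what the source reports. "The series", "measured", "known", "first", "only" and "open" are said of these compounds alone.

Within the data shown here, compound 3 `CC(C)C(Nc1nccs1)c1ccc(-c2ccc3cccc(F)c3c2)[nH]c1=O` is the one member of this small set with a number rather than a limit in an ADME assay on microsomes from liver (Rattus norvegicus) for metabolic stability; on this read-out higher numbers stand for a longer-lived compound and lower numbers for a shorter-lived compound: in that assay compound 3 gives 0.07 h. Compound 1 `CC(C)C(c1ncc[nH]1)c1ccc(-c2ccc3cccc(F)c3c2)[nH]c1=O` returns only a limit in this assay, < 0.0667 h. Compound 2 `CC(C)NC(=O)CC(c1ccc(-c2ccc3cccc(F)c3c2)[nH]c1=O)C(C)C` likewise returns only a limit in this assay, < 0.0667 h. Compound 4 `CC(C)C(Cc1ncc[nH]1)c1ccc(-c2ccc3cccc(F)c3c2)[nH]c1=O` differs from compound 3 in one place: (1H-imidazol-2-yl)methyl in place of (1,3-thiazol-2-yl)amino on a saturated chain carbon bound to an aromatic carbon and a saturated chain carbon. The measured steps touching this position are an at least 1.0-fold higher number from compound 1 to compound 3 (0.02 log units; that floor lies within the scatter) and an at least 1.0-fold higher number from compound 2 to compound 3 (0.02 log units; that floor lies within the scatter), both floors within the scatter, so they fix no direction. Compound 1, which also carries a 1H-imidazol-2-yl group, sits at the limit of < 0.0667 h in this assay, at which 2 of the 3 values shown sit. Compound 4 is therefore expected to shift a 1.2-fold lower number from compound 3 to compound 4 (0.07 log units; within the scatter), with an estimate of 0.06 h between 0.03 h and 0.12 h.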

Compound 4, half-life: < 0.0667 h
Compound 4 was reported as a limit; the forecaster's own chance of this, stated with the estimate: 60%; the middle value lies beyond the limit too.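

Putting (1H-imidazol-2-yl)methyl on this saturated chain carbon gives an at least 1.0-fold lower number from compound 3 to compound 4 (0.02 log units; that floor lies within the scatter), so the change from (1,3-thiazol-2-yl)amino shows no direction in this assay. The steps from compound 1 and from compound 2 to compound 4 join two limits and cannot be read. A second imidazole-bearing arm adds to the cluster at the bottom of the assay's range: the limit of < 0.0667 h in this assay, at which 3 of the 4 values shown sit.

Going by these compounds, how far the compounds reported as limits actually differ stays open. So does whether an amine or a carboxylic acid on this carbon would lift the half-life clear of that limit.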